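Toward an aminophenyl analogue of a chromone-bearing kinase inhibitor

The source may report more compounds than this note shows. Statements on the series, on what has been measured and on what is new or still open speak of the compounds shown alone.

Measured compounds:
compound 1 `COc1ccc(OCC(=O)Nc2cccc(NC(=O)c3ccc(N(C)C)cc3)c2)cc1OC`: > 10000 nM
compound 2 `COc1ccc(OCC(=O)Nc2cccc(NC(=O)c3ccc(N(C)C)cc3)c2)cc1F`: 1820 nM
compound 3 `O=C(COc1ccc2c(=O)ccoc2c1)Nc1cccc(NC(=O)c2ccc([N+](=O)[O-])cc2)c1`: 67 nM

Of the compounds shown here, three share a core and have been tested in an assay on isolated protein for inhibition of Rho-associated protein kinase 1 (Homo sapiens), read by scintillation counting, radiometric assay and 33P incorporation, with a stated time of 40 min, in the presence of a further agent that is not named here; on this read-out lower numbers stand for stronger inhibition and higher numbers for weaker inhibition. Compound 1 gives only a limit, > 10000 nM, and not a number. Compound 2 gives 1820 nM, and the change of fluoro in place of methoxy on an aromatic carbon reads as an at least 5.4-fold lower number from compound 1 to compound 2 (0.73 log units; beyond the scatter). Compound 3 gives 67 nM and stands lowest of the two numbers shown, with compound 2 as its nearest neighbour a good deal higher.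

Compound 4 `Nc1cccc(C(=O)Nc2cccc(NC(=O)COc3ccc4c(=O)ccoc4c3)c2)c1` is not yet measured. It differs from compound 3 as follows: 3-aminophenyl in place of 4-nitrophenyl on a carbonyl carbon. No measured step touches this part of the molecule; the only step shown, that from compound 1 to compound 2, concerns a different ring. The expectation for compound 4 therefore rests on compound 3 alone, with a wide margin in either direction. Compound 4 is expected to give about 300 nM in this assay, within 50 nM to 2000 nM, a step of a 4.5-fold higher number from compound 3 to compound 4 (0.65 log units; beyond the scatter).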

Compound 4, half-maximal inhibitory concentration: 670 nM
Compound 4: middle estimate off by 2.2-fold (0.35 log units), on the low side, and the stated range covers the measured number.
By their numbers in this assay, from the lowest: compound 3; then compound 4; then compound 2. At a limit, above all of these: compound 1.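

The aryl group on the carbonyl carbon is shown here for the first time to bear on this assay: 3-aminophenyl in place of 4-nitrophenyl gives a 10-fold higher number from compound 3 to compound 4 (1.00 log units; beyond the scatter). Compound 4 still gives a measured number, 670 nM, so with this core the change weakens inhibition without abolishing it. The names show that the step replaces the nitro group with an amine and also alters where the group sits on the phenyl ring, and the two changes cannot be told apart. Nothing measured here gives a reason for the step.

The compounds shown leave open how the amine and the nitro group would each compare at the other's place on the ring. They also leave open how a nitrile or a carboxylic acid would fare on that ring.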